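Trading the Amino Side Chain for a Cyclopentyl Thioether

The compounds below may be only part of what the source reports. "The series", "measured", "known", "first", "only" and "open" are said of these compounds alone.

Compounds measured so far:
Compound 1 `CCCCN(C)c1nc(C(C)(C)C)ccc1CNC(=O)C(C)c1ccc(NS(C)(=O)=O)c(F)c1`: 1.2 nM
Compound 2 `CCCN(CCC)c1nc(C(C)(C)C)ccc1CNC(=O)C(C)c1ccc(NS(C)(=O)=O)c(F)c1`: 2.5 nM
Compound 3 `CCOc1nc(C(C)(C)C)ccc1CNC(=O)C(C)c1ccc(NS(C)(=O)=O)c(F)c1`: 14.8 nM

In an assay on cells for antagonist activity at transient receptor potential cation channel subfamily V member 1 (Homo sapiens), read by FLIPR and calcium flux, with a stated time of 6 min (a higher number here means a weaker inhibitor, a lower number a stronger inhibitor), compound 1 stands lowest of the three numbers, so it is the strongest inhibitor here. Its nearest neighbour is compound 2, and the step of a 2.1-fold higher number from compound 1 to compound 2 (0.32 log units; beyond the scatter) shows that the change from butyl(methyl)amino to dipropylamino costs only a little. Moving to ethoxy costs far more: a 12-fold higher number from compound 1 to compound 3 (1.09 log units; beyond the scatter) is large, and a 5.9-fold higher number from compound 2 to compound 3 (0.77 log units; beyond the scatter) points the same way from compound 2.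

Compound 4 `CC(C(=O)NCc1ccc(C(C)(C)C)nc1SC1CCCC1)c1ccc(NS(C)(=O)=O)c(F)c1` has not yet been measured. It differs from compound 1 in one place (cyclopentylsulfanyl in place of butyl(methyl)amino on an aromatic carbon). The entering group keeps the same heavy-atom count and the same single acceptor as the group it replaces, so the change resembles the step to compound 2 more than the step to compound 3, where a much smaller group entered. The expectation is therefore a modest weakening in this assay, somewhat beyond the scatter, rather than a large one, because a 2.1-fold higher number from compound 1 to compound 2 (0.32 log units; beyond the scatter) shows that a bulky group at this position is tolerated. Compound 4 is expected to give about 3.5 nM in this assay, within a range of 1.2 nM to 12 nM. That estimate corresponds to an expected step of a 2.9-fold higher number from compound 1 to compound 4 (0.46 log units; beyond the scatter).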

Compound 4, inhibition constant: 2.5 nM
Beside the measured number, compound 4's estimate is 1.4-fold (0.15 log units) above it; measured number inside the range.
By their numbers in this assay, from the lowest: compound 1; then compounds 2 and 4 (each within the scatter of the next); then compound 3.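

A nitrogen attached to the aromatic carbon is not needed for strong inhibition here: cyclopentylsulfanyl, which links through sulfur and brings in a ring, gives a 2.1-fold higher number from compound 1 to compound 4 (0.32 log units; beyond the scatter) and so remains in the low range set by the two amino compounds. Replacing the open-chain dipropylamino with this ring gives no change at the digits printed from compound 2 to compound 4 (within the scatter) and shows that, for this pair, the two groups cannot be told apart. Replacing ethoxy gives a 5.9-fold lower number from compound 3 to compound 4 (0.77 log units; beyond the scatter) and shows that a group other than an amine can also give a lower number than ethoxy.

Nothing available explains why these groups compare as they do. Going by these compounds, it also remains open how a smaller cyclopropylsulfanyl group or a piperidine ring attached through its nitrogen would compare at this position.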